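This account rests on a few compounds, and the source may have more. Where it says the series, first, only, none or still open, it means among the compounds named here.

Measured so far:
- compound 1, `COc1ncnc2c1c(-c1cccs1)cn2[C@@H]1O[C@H](CO)[C@@H](O)[C@H]1O`: 12100 nM
- compound 2, `COc1nc(N)nc2c1c(-c1cccs1)cn2[C@@H]1O[C@H](CO)[C@@H](O)[C@H]1O`: > 20000 nM
- compound 3, `O=c1[nH]cnc2c1c(-c1ccco1)cn2[C@@H]1O[C@H](CO)[C@@H](O)[C@H]1O`: > 20000 nM

In a functional assay on CEM-DNR-bulk cells (Homo sapiens), read by MTT assay, with a stated time of 72 h (a higher number here means a weaker inhibitor, a lower number a stronger inhibitor), compound 1 gives 12100 nM. For compound 2 the reading is > 20000 nM, which is a limit of the assay and not a number. For compound 3 the reading is likewise a limit, > 20000 nM. For the measured compounds named here, the one measured step is an at least 1.6-fold higher number from compound 1 to compound 2 (0.21 log units; that floor lies within the scatter), made by the change (amino in place of hydrogen on an aromatic carbon); its size cannot be pinned down more closely because of the limit of > 20000 nM in this assay, at which 2 of the 3 values shown sit.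

Compound 4, `Nc1nc2c(c(-c3ccco3)cn2[C@@H]2O[C@H](CO)[C@@H](O)[C@H]2O)c(=O)[nH]1`, is not yet measured. Going by the values given here, it arises from compound 3 by amino in place of hydrogen on an aromatic carbon, the same kind of change as the one made from compound 1 to compound 2, though the surroundings differ: in compound 1 the new group lands meta to a methoxy group (2 heavy atoms), in compound 3 meta to a group of 1 heavy atom. How the core of compound 3 differs from the core of compound 1 is not broken down here.

Compound 4 is expected to give about 30000 nM, and most likely again only a limit. That expectation rests on compound 3 and its limit > 20000 nM. The expected step is a step that the limit leaves unreadable from compound 3 to compound 4, set beside the measured at least 1.6-fold higher number from compound 1 to compound 2 (0.21 log units; that floor lies within the scatter), in which the same kind of change did not yield a stronger inhibitor.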

Compound 4, half-maximal inhibitory concentration: > 20000 nM
Compound 4: a limit, no number; the forecaster's own chance of this, stated with the estimate: 85%; the middle value is on the limit's open side.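

In this assay compound 4 gives > 20000 nM, which is a limit of the assay and not a number. Compound 3 also sits at a limit, so no step from compound 3 to compound 4 can be read: the limit of > 20000 nM in this assay, at which 3 of the 4 values shown sit.

The compounds shown leave open what actual readings compound 2, compound 3 and compound 4 would give, and so whether amino in place of hydrogen on an aromatic carbon changes the reading at all.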